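The source may report more compounds than this note shows. Statements on the series, on what has been measured and on what is new or still open speak of the compounds shown alone.

Measured compounds:

Compound 1, `O=c1c2ccccc2nc(CSc2nnc(-c3ccncc3)o2)n1/N=C/c1ccc(O)cc1`: 18.2%
Compound 2, `O=c1c2ccccc2nc(CSc2nnc(-c3ccncc3)o2)n1/N=C/c1ccc(Cl)cc1`: 23.7%
Compound 3, `O=C1CSC(c2ccc(O)cc2)N1n1c(CSc2nnc(-c3ccncc3)o2)nc2ccccc2c1=O`: 31.7%

The three compounds were examined in a functional assay on the whole organism (strain Charles-Foster albino) for inhibition, with Rattus norvegicus as the target, read by paw edema, at a dose of 50 mg/kg by the oral route; a lower number here means less inhibition, a higher number more inhibition at the dose given (going by the name of the read-out). Compound 1 and compound 2 share one core and differ in a single place, the change being (chloro in place of hydroxy on an aromatic carbon). This change gave a number 5.5 percentage points higher from compound 1 to compound 2 (within the scatter). Compound 3 carries a second core; how it differs from the core of compound 1 is not broken down here. Compound 4, `O=C1CSC(c2ccc(Cl)cc2)N1n1c(CSc2nnc(-c3ccncc3)o2)nc2ccccc2c1=O`, has not yet been measured in this assay; it stands to compound 3 exactly as compound 2 stands to compound 1, the same change at the same kind of place, namely (chloro in place of hydroxy on an aromatic carbon). Since the change occurs only once more among the compounds shown, the expectation rests on that single earlier step, and the step is expected to be small, about a number 4.3 percentage points higher from compound 3 to compound 4 (within the scatter), because a number 5.5 percentage points higher from compound 1 to compound 2 (within the scatter) was within the usual scatter. Compound 4 is therefore estimated at 36%, with a range from 25% to 48%.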

Compound 4, a percentage reported as inhibition, in the whole organism at one dose (the size of the read-out at that dose, not a potency): 34.1%
Beside the measured number, compound 4's estimate is 1.9 percentage points above it, within the range that was stated.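

In this assay, chloro in place of hydroxy gave a number 2.4 percentage points higher from compound 3 to compound 4 (within the scatter). Both steps with this change lie within the scatter, so neither core shows an effect of the swap that stands clear of repeat measurement. The change therefore carries across these two cores without a discernible difference, though two small steps establish no rule for any other core, and they cannot show that the change would do the same where its effect is larger: the same change on two cores in this assay, a number 5.5 percentage points higher (within the scatter) from compound 1 to compound 2 and a number 2.4 percentage points higher (within the scatter) from compound 3 to compound 4, 3.1 percentage points apart, within the scatter of two such steps

From the compounds shown here alone, only hydroxy and chloro appear at this place on the aromatic ring, so how an amine or a carboxylic acid there would read remains open. Also open, going by these compounds, is whether the two cores would still match at another dose.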